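Compound 4 against a series near the assay limit

This account rests on a few compounds, and the source may have more. Where it says the series, first, only, none or still open, it means among the compounds named here.

- compound 1 `COC(=O)CC/C(C)=C/Cc1c(OC)c(C)c2c(c1OCC#CCN1CCN(c3ccc(C#N)cc3)CC1)C(=O)OC2`: > 50000 nM (a limit, not a number)
- compound 2 `COC(=O)CC/C(C)=C/Cc1c(OC)c(C)c2c(c1OCC#CCN1CCN(c3ccccc3F)CC1)C(=O)OC2`: 45300 nM
- compound 3 `COC(=O)CC/C(C)=C/Cc1c(OC)c(C)c2c(c1OCC#CCN1CCN(c3ccc(O)cc3)CC1)C(=O)OC2`: > 50000 nM (a limit, not a number)

All three values come from a functional assay on A549 cells (Homo sapiens) for inhibition, read by sulforhodamine B assay; on this read-out higher numbers stand for weaker inhibition and lower numbers for stronger inhibition. Compound 3 has no number, only the limit > 50000 nM. Compound 1 stands at the same limit, as the limit of > 50000 nM in this assay, at which 2 of the 3 values shown sit, records. Compound 2 alone has a number, 45300 nM.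

Compound 4 `COC(=O)CC/C(C)=C/Cc1c(OC)c(C)c2c(c1OCC#CCN1CCN(Cc3ccc(Cl)cc3)CC1)C(=O)OC2` carries 4-chlorobenzyl in place of 4-hydroxyphenyl on an amine nitrogen in a ring. Among the measured compounds shown here, no measured compound has a 4-chlorobenzyl group, so the closest guide is the set of changes at this same nitrogen. The measured steps are an at least 1.1-fold lower number from compound 1 to compound 2 (0.04 log units; that floor lies within the scatter) and an at least 1.1-fold higher number from compound 2 to compound 3 (0.04 log units; that floor lies within the scatter), and both floors lie within the scatter. The third, a step that the two limits leave unreadable from compound 1 to compound 3, cannot be read. These steps show no substituent change at this nitrogen that moves the read-out beyond the scatter, although the limits could hide larger differences.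

In this assay, no step beyond the scatter is therefore expected, and no firm direction. The expected step is an at least 1.1-fold lower number from compound 3 to compound 4 (0.07 log units; that floor lies within the scatter). For compound 4 the estimated value is 42000 nM, with an expected range of 15000 nM to 70000 nM.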

Compound 4, half-maximal inhibitory concentration: > 50000 nM
Compound 4: a limit, no number; the forecaster's own chance of this, stated with the estimate: 50%; middle value at least 1.1-fold (0.07 log units) from the limit.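

Compound 4 gives > 50000 nM in this assay, which is a limit and not a number, so a benzyl-type group with no hydrogen-bond donor or acceptor on this amine nitrogen also gives no measurable value here. Among the compounds shown here, the one readable step is an at least 1.1-fold higher number from compound 2 to compound 4 (0.04 log units; that floor lies within the scatter), and the steps to compound 1 and compound 3 cannot be read. The position has now taken four different groups without any step beyond the scatter, and the values gather at one limit: the limit of > 50000 nM in this assay, at which 3 of the 4 values shown sit.

Going by these compounds, how far compound 1, compound 3 and compound 4 lie past that limit stays unknown, so no order among them can be drawn. On these data alone, whether an unsubstituted benzyl or a 2-fluorobenzyl group on this nitrogen, or a carboxylic acid in place of the methyl ester on the side chain of the shared core, would give a clear number in this assay remains open.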